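The compounds below may be only part of what the source reports. "The series", "measured", "known", "first", "only" and "open" are said of these compounds alone.

Working notes on the series. Compound 1 `COc1cc(-c2nn(-c3cccc(NC(=O)c4cccc(C(F)(F)F)c4)c3)cc2-c2ccncc2)ccc1Cl`, compound 2 `COc1cc(-c2nn(-c3cccc(NC(=O)Nc4ccc(Cl)c(Cl)c4)c3)cc2-c2ccncc2)ccc1Cl` and compound 3 `COc1cc(-c2nn(-c3cccc(NC(=O)Nc4cccc(C(F)(F)F)c4)c3)cc2-c2ccncc2)ccc1Cl` share one core and differ only in what sits on the carbonyl carbon. In a functional assay on UO-31 cells (Homo sapiens) for inhibition, read by sulforhodamine B assay, with a stated time of 48 h (on this read-out higher numbers stand for weaker inhibition of growth and lower numbers for stronger inhibition of growth), compound 1 gives 968 nM, compound 2 gives 845 nM and compound 3 gives 702 nM. Compound 3 stands with the lowest of the three numbers, but a 1.2-fold lower number from compound 2 to compound 3 (0.08 log units; within the scatter) and a 1.4-fold lower number from compound 1 to compound 3 (0.14 log units; within the scatter) both stay within the scatter, so no order is established. Compound 4 `COc1cc(-c2nn(-c3cccc(NC(=O)c4ccc(Cl)c(C(F)(F)F)c4)c3)cc2-c2ccncc2)ccc1Cl` is not yet measured; it arises from compound 3 by 4-chloro-3-(trifluoromethyl)phenyl in place of (3-(trifluoromethyl)phenyl)amino on a carbonyl carbon. The nearest precedents are a 1.4-fold lower number from compound 1 to compound 3 (0.14 log units; within the scatter), which runs in the opposite sense, and a 1.1-fold lower number from compound 1 to compound 2 (0.06 log units; within the scatter), each within the scatter. A small move is therefore expected, a 1.3-fold higher number from compound 3 to compound 4 (0.11 log units; within the scatter), toward a slightly higher number. Compound 4 is estimated at 900 nM, with a range from 450 nM to 1800 nM.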

Compound 4, concentration for 50% growth inhibition: 267 nM
For compound 4 the middle estimate is 3.4-fold (0.53 log units) above the measured one; the whole stated range lies above it.
By their numbers in this assay, from the lowest: compound 4; then compounds 3, 2 and 1 (each within the scatter of the next).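

In this assay, chloro in place of hydrogen on an aromatic carbon gives a 3.6-fold lower number from compound 1 to compound 4 (0.56 log units; beyond the scatter) and produces the first separation beyond the scatter in the series. The same 4-chloro-3-(trifluoromethyl)phenyl group on the carbonyl carbon also gives a 2.6-fold lower number from compound 3 to compound 4 (0.42 log units; beyond the scatter) and a 3.2-fold lower number from compound 2 to compound 4 (0.50 log units; beyond the scatter) when it replaces the arylamino groups, whereas swapping those groups among compounds 1, 2 and 3 moved nothing beyond the scatter. No measurement on hand explains this gain. On these data alone, whether bromo, methyl or an amine in place of that chloro would keep the lower number remains open.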